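Compound 3 to compound 4: bromo in place of methoxy

The source may report more compounds than this note shows. Statements on the series, on what has been measured and on what is new or still open speak of the compounds shown alone.

In a functional assay on SGC-7901 cells (Homo sapiens) for inhibition, read by MTT assay, with a stated time of 72 h (on this read-out lower numbers stand for stronger inhibition and higher numbers for weaker inhibition), compound 1 `Cc1ccc(N2CCCC2)c(C(=O)Nc2ccc(CNC(=O)OCc3cccnc3)cc2)c1` gives 65300 nM and compound 3 `COc1ccc(N2CCCC2)c(C(=O)Nc2ccc(CNC(=O)OCc3cccnc3)cc2)c1` gives 47200 nM so that these two numbers lie within the scatter of each other. Compound 2 `O=C(NCc1ccc(NC(=O)c2cccc(F)c2N2CCCC2)cc1)OCc1cccnc1` marks the limit of > 100000 nM in this assay, at which 1 of the 3 values shown sits, and its entry is a limit, not a number (> 100000 nM). For the measured compounds named here, compound 3 therefore stands level with compound 1 on the only two numbers available, both in the high micromolar part of the scale.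

Compound 4 `O=C(NCc1ccc(NC(=O)c2cc(Br)ccc2N2CCCC2)cc1)OCc1cccnc1` carries bromo in place of methoxy on an aromatic carbon, para to a pyrrolidin-1-yl group (bromo in place of methoxy on an aromatic carbon). Going by the values given here, the one measured step at that carbon, methoxy in place of methyl, gave a 1.4-fold lower number from compound 1 to compound 3 (0.14 log units; within the scatter) and so offers no sign of sensitivity to the group there. Among the compounds with values here, no bromo compound has yet been measured, so this single step is weak support. No step beyond the scatter is expected in this assay for this change. The expected step is a 1.0-fold lower number from compound 3 to compound 4 (0.02 log units; within the scatter) and a reading as a limit remains possible. For compound 4 the estimated value is 45000 nM with an expected range from 18000 nM to 95000 nM in repeated measurements.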

Compound 4, half-maximal inhibitory concentration: > 100000 nM
Compound 4: no number, only a limit; the forecaster's own chance of this, stated with the estimate: 20%; middle value at least 2.2-fold (0.34 log units) from the limit.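

In this assay, for the compounds shown here, the carbon para to a pyrrolidin-1-yl group now shows a response to the group it carries: bromo in place of methoxy gives an at least 2.1-fold higher number from compound 3 to compound 4 (0.32 log units; beyond the scatter), the first step at this carbon that lies beyond the scatter. Against the methyl compound the reading is less firm, since bromo in place of methyl gives an at least 1.5-fold higher number from compound 1 to compound 4 (0.18 log units; that floor lies within the scatter), and this comparison alone does not separate those two groups. The reading for compound 4 is a limit and not a number, so only a floor is known for both steps, and the series now has a second entry of this kind: the limit of > 100000 nM in this assay, at which 2 of the 4 values shown sit.

Methoxy, methyl and bromo are too few to show what this carbon tolerates, and it remains open how an amine, a hydroxyl or a carboxylic acid would read there. Also open, going by these compounds, is whether any group at this carbon can bring the series clear of the high micromolar part of the scale, or whether that would take a change elsewhere on the shared core, such as a longer chain in place of the pyrrolidin-1-yl group.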